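Tetrazole in place of nitrile on the biaryl series

The source may report more compounds than this note shows. Statements on the series, on what has been measured and on what is new or still open speak of the compounds shown alone.

Compound 1 `C[C@@H](Nc1nccc(Cl)c1NC(=O)CC#N)c1ccc(-c2cccc(F)c2C#N)cc1` gives "not determined" (no result reported) in a functional assay on CHO cells for antagonist activity at B1 bradykinin receptor (Homo sapiens), read by FLIPR and calcium flux; a higher number here means a weaker inhibitor, a lower number a stronger inhibitor; no result was reported for it. Compound 2 `COC(=O)c1c(Cl)cccc1-c1ccc([C@@H](C)Nc2nccc(Cl)c2NC(=O)CC#N)cc1` gives 0.85 nM in this assay, which places the shared core among strong inhibitors. Compound 3 `C[C@@H](Nc1nccc(Cl)c1NC(=O)CC#N)c1ccc(-c2cccc(F)c2-c2nnn(C)n2)cc1` differs from compound 1 by 2-methyl-2H-tetrazol-5-yl in place of cyano on an aromatic carbon. Going by the values given here, no measured pair isolates this change, so the size of the step in this assay is open; a modest shift, in either direction and possibly not beyond the scatter, is expected. Compound 3 is estimated to give 3 nM in this assay, within a range from 0.5 nM to 20 nM.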

Compound 3, half-maximal inhibitory concentration: 1.17 nM
The estimate for compound 3 lay 2.6-fold (0.41 log units) above the measured number, and the stated range covers the measured number.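

No step can be read between compound 1 and compound 3 in this assay. On these data alone, the effect of 2-methyl-2H-tetrazol-5-yl in place of cyano on the shared core stays open. No supporting evidence bears on this result.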